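Swapping Chlorophenyl for Thiophenyl in a Shared Core

A few compounds are considered here, and "the series" means these few. Any claim that something is new, unique, unknown or untested is made for them only; others in the source may bear on it.

Of the compounds shown here, two built on one shared core have been measured so far. In a functional assay on CCRF-CEM cells (Homo sapiens) for antiproliferative activity, read by resazurin assay, with a stated time of 72 h (a lower number here means a stronger inhibitor, a higher number a weaker inhibitor), compound 1 `COc1ccc(-c2nc3c(c(-c4ccccc4)nn3-c3ccccc3)c(-c3ccc(O)cc3)c2C#N)cc1` gives 6700 nM. Compound 2 `N#Cc1c(-c2ccc(Cl)cc2)nc2c(c(-c3ccccc3)nn2-c2ccccc2)c1-c1ccc(O)cc1` gives 43100 nM in this assay. The two differ in a single place, compound 2 carrying a chloro group where compound 1 carries methoxy, and this change brought a 6.4-fold higher number from compound 1 to compound 2 (0.81 log units; beyond the scatter). Compound 2 therefore holds the higher of the two numbers and is the weaker inhibitor of the pair.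

Compound 3 `N#Cc1c(-c2cccs2)nc2c(c(-c3ccccc3)nn2-c2ccccc2)c1-c1ccc(O)cc1` has not yet been measured. It differs from compound 2 as follows: thiophen-2-yl in place of 4-chlorophenyl on an aromatic carbon. Among the compounds with values here, the only measured step concerns the group that now leaves, where swapping methoxy for chloro gave a 6.4-fold higher number from compound 1 to compound 2 (0.81 log units; beyond the scatter), so the value in this assay is clearly sensitive to what sits there. Within the data shown here, replacing the whole ring is a larger change than that step, and no measured pair shows its direction. A modest move, more likely toward a lower number, is expected. Compound 3 is estimated at 15000 nM, between 4000 nM and 60000 nM, which would mean a step of a 2.9-fold lower number from compound 2 to compound 3 (0.46 log units; beyond the scatter).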

Compound 3, half-maximal inhibitory concentration: > 25000 nM
Compound 3 ended at the assay's limit; the forecaster's own chance of this, stated with the estimate: 10%; middle value at least 1.6-fold (0.22 log units) away from the limit.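

In this assay, the result for compound 3 is a limit of the assay and not a number: the limit of > 25000 nM in this assay, at which 1 of the 3 values shown sits. As far as these compounds go, the step from the chloro compound to the thiophene compound therefore cannot be read, and the order of 4-chlorophenyl and thiophen-2-yl at this place stays unknown. The comparison with the methoxy compound can be read, and it adds a replacement of the whole ring: thiophen-2-yl in place of 4-methoxyphenyl gives an at least 3.7-fold higher number from compound 1 to compound 3 (0.57 log units; beyond the scatter), alongside the earlier 6.4-fold higher number from compound 1 to compound 2 (0.81 log units; beyond the scatter), so the 4-methoxyphenyl group gives the lowest number of the three groups shown on this aromatic carbon next to the ring nitrogen.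

Still open, from the compounds shown here alone, is whether another group on this carbon, such as a phenyl ring carrying an amine or a longer ether chain, would match or beat 4-methoxyphenyl. Going by these compounds, the cyano and 4-hydroxyphenyl groups are the same in all three compounds, so what either of them contributes to the numbers, and what a carboxylic acid in place of the cyano group would do, also remains open.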